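Bromo in place of isopropyl on the five-membered ring

A few compounds are considered here, and "the series" means these few. Any claim that something is new, unique, unknown or untested is made for them only; others in the source may bear on it.

Measured so far in an assay for inhibition of ribosomal protein S6 kinase beta-1 variant D18H,T412E (Homo sapiens), read by a luciferase reporter and chemiluminescence, with a stated time of 3 h; on this read-out higher numbers stand for weaker inhibition and lower numbers for stronger inhibition:
- compound 1, `Cc1ccc(Cl)cc1N1CCN(c2ncnc3[nH]ncc23)CC1`, 13 nM
- compound 2, `Cc1ccc(Cl)cc1N1CCN(c2ncnc3[nH]nc(C)c23)CC1`, 9 nM
- compound 3, `Cc1ccc(Cl)cc1N1CCN(c2ncnc3[nH]nc(C(C)C)c23)CC1`, 16 nM

Compound 3 holds the highest number of the three, but the two steps that reach it are a 1.2-fold higher number from compound 1 to compound 3 (0.09 log units; within the scatter) and a 1.8-fold higher number from compound 2 to compound 3 (0.25 log units; within the scatter), so none of the three is separated from the others beyond the scatter. The shared core tolerates hydrogen, methyl and isopropyl at this carbon without a change that can be read.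

Compound 4, `Cc1ccc(Cl)cc1N1CCN(c2ncnc3[nH]nc(Br)c23)CC1`, is the next member. It differs from compound 3 by bromo in place of isopropyl on an aromatic carbon; the place is on an aromatic carbon of a five-membered aromatic ring with 2 nitrogen, part of a fused or bridged system of two rings, next to the ring nitrogen. Among the measured compounds shown here, the steps that bear on it are a 1.4-fold lower number from compound 1 to compound 2 (0.16 log units; within the scatter), a 1.2-fold higher number from compound 1 to compound 3 (0.09 log units; within the scatter) and a 1.8-fold higher number from compound 2 to compound 3 (0.25 log units; within the scatter), each within the scatter. Bromo itself has no precedent in this set, so the expectation rests only on the flat trend across hydrogen, methyl and isopropyl. The expected step is a 1.3-fold lower number from compound 3 to compound 4 (0.12 log units; within the scatter), no change beyond the scatter. Compound 4 is therefore estimated at 12 nM, with a range from 5 nM to 30 nM.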

Compound 4, half-maximal inhibitory concentration: 7 nM
Beside the measured number, compound 4's estimate is 1.7-fold (0.23 log units) above it; measured number inside the range.
By their numbers in this assay, from the lowest: compounds 4, 2, 1 and 3 (each within the scatter of the next, the first and the last beyond it).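

In this assay, among the compounds shown here, bromo gives the only step in this set that lies beyond the scatter, a modest one: a 2.3-fold lower number from compound 3 to compound 4 (0.36 log units; beyond the scatter) when bromo, with its 1 heavy atom, replaces isopropyl, with its 3 carbon atoms, on this aromatic carbon of the five-membered ring. For the compounds shown here, the other two new steps stay within the scatter, a 1.3-fold lower number from compound 2 to compound 4 (0.11 log units; within the scatter) and a 1.9-fold lower number from compound 1 to compound 4 (0.27 log units; within the scatter), so bromo cannot be told apart from methyl or hydrogen here, and the position remains tolerant of these groups, with only the pair of bromo and isopropyl separated. Nothing available explains the separation between these two groups.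

From the compounds shown here alone, whether chloro or iodo would fall with bromo remains open, as does the effect of an amine, a methoxy group or a carboxylic acid on this carbon. Also open, going by these compounds, is whether the separation between bromo and isopropyl would persist with other parts of the shared core changed, since all four compounds carry the same remainder.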